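The compounds below may be only part of what the source reports. "The series", "measured", "known", "first", "only" and "open" are said of these compounds alone.

Compound 1 `Cc1nn(C)c(-n2cccc2)c1/C=N/OCc1ccc(C(=O)OC(C)(C)C)cc1`: 2.48 ug/mL
Compound 2 `Cc1nn(C)c(-n2ccnc2)c1/C=N/OCc1ccc(C(=O)OC(C)(C)C)cc1`: 8.67 ug/mL

Of the compounds shown here, two sharing one core have been measured in a functional assay on HCT-15 cells (Homo sapiens) for cytotoxicity; on this read-out lower numbers stand for stronger inhibition and higher numbers for weaker inhibition. Compound 1 gives 2.48 ug/mL, and compound 2 gives 8.67 ug/mL. Among the compounds with values here, compound 2 thus stands at the higher of the two numbers, the weaker of the two; its nearest neighbour is compound 1, and the only measured step is a 3.5-fold higher number from compound 1 to compound 2 (0.54 log units; beyond the scatter). That step swapped a five-membered ring of carbon only for one carrying two nitrogens, and the number rose.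

Compound 3 `Cc1nn(C)c(Sc2ccccc2)c1/C=N/OCc1ccc(C(=O)OC(C)(C)C)cc1` is the next compound in the series and has not been measured. It differs from compound 2 in one place: phenylsulfanyl in place of 1H-imidazol-1-yl on an aromatic carbon. Within the data shown here, the incoming group again carries a ring of carbon only, so the single measured step is the one that bears on it, and it suggests a modest move back downward rather than no change. On that basis compound 3 is expected to show a 2.9-fold lower number from compound 2 to compound 3 (0.46 log units; beyond the scatter). The estimate for compound 3 is 3 ug/mL, with a range from 1.2 ug/mL to 8 ug/mL.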

Compound 3, half-maximal inhibitory concentration: 0.26 ug/mL
Beside the measured number, compound 3's estimate is 12-fold (1.06 log units) above it; the whole stated range lies above it.
By their numbers in this assay, from the lowest: compound 3; then compound 1; then compound 2.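

In this assay, within the data shown here, this position turns out to be far more sensitive than the first pair suggested: phenylsulfanyl in place of 1H-imidazol-1-yl gives a 33-fold lower number from compound 2 to compound 3 (1.52 log units; beyond the scatter) and so outweighs the only earlier step, which was a 3.5-fold higher number from compound 1 to compound 2 (0.54 log units; beyond the scatter) at the same carbon. Phenylsulfanyl in place of 1H-pyrrol-1-yl gives a 9.5-fold lower number from compound 1 to compound 3 (0.98 log units; beyond the scatter) as well, so the new group does not merely return the number to the level of compound 1 but takes it past both earlier compounds, showing that this position accepts a six-membered ring joined through sulfur. Nothing available here explains why this change has so large an effect.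

Phenylsulfanyl differs from both earlier groups in its ring and in its sulfur link at once, so the compounds shown cannot tell which of these matters. A phenoxy group, with oxygen in place of the sulfur, or a phenyl ring joined directly to the core would help separate the two, and a substituted phenylsulfanyl ring would show how much further this position can be taken.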